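The source may report more compounds than this note shows. Statements on the series, on what has been measured and on what is new or still open speak of the compounds shown alone.

Measured in a functional assay on HCT-116 cells (Homo sapiens) for antiproliferative activity, read by MTT assay, with a stated time of 48 h; a lower number here means a stronger inhibitor, a higher number a weaker inhibitor:
Compound 1 `CCn1c(=O)n(-c2cc(OC)c(OC)c(OC)c2)c2cc(-c3ccc(OC)c(O)c3)ncc21`: > 20000 nM
Compound 2 `COc1ccc(-c2cc3c(cn2)n(C(C)C)c(=O)n3-c2cc(OC)c(OC)c(OC)c2)cc1O`: 6660 nM

Compound 1 reads > 20000 nM, which is a limit and not a number, as the limit of > 20000 nM in this assay, at which 1 of the 2 values shown sits, records. Going by the values given here, compound 2, at 6660 nM, therefore holds the only true number so far.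

The next compound is compound 3 `COc1ccc(-c2cc3c(cn2)n(CC(N)=O)c(=O)n3-c2cc(OC)c(OC)c(OC)c2)cc1O`, which has carbamoylmethyl in place of isopropyl on an aromatic nitrogen. Among the compounds with values here, only one measured step bears on this change, and it concerns the chain on that same nitrogen: an at least 3.0-fold lower number from compound 1 to compound 2 (0.47 log units; beyond the scatter). That step is modest and beyond the scatter. Within the data shown here, it shows that this assay can respond to a small change in this group, but no measured compound carries carbamoylmethyl. Compound 3 gives up the isopropyl of compound 2, so a modest move toward a higher number is expected, and a result reported only as a limit would be no surprise.

Compound 3 is expected at 14000 nM, with an estimated range of 5000 nM to 40000 nM. The expected change is a 2.1-fold higher number from compound 2 to compound 3 (0.32 log units; beyond the scatter).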

Compound 3, half-maximal inhibitory concentration: 8890 nM
Compound 3: the middle estimate sits 1.6-fold (0.20 log units) above what was measured; measured number inside the range.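

In this assay, the substituent on this aromatic nitrogen turned out to tolerate a large swap of character, since carbamoylmethyl, which brings the hydrogen-bond donor and acceptor counted for it, stands level with the isopropyl it replaces: a 1.3-fold higher number from compound 2 to compound 3 (0.13 log units; within the scatter). The earlier compounds had shown only that adding a methyl to the chain carbon bound to this nitrogen could move the number, whereas the new comparison with compound 1 shows that carbamoyl on that same carbon serves as well, with an at least 2.2-fold lower number from compound 1 to compound 3 (0.35 log units; beyond the scatter). So among the three compounds, the two with a substituted chain carbon give true numbers, and only the unbranched chain of compound 1 does not, although compound 1 reads as a limit and not a number, which leaves the size of both steps from it bounded on one side only: the limit of > 20000 nM in this assay, at which 1 of the 3 values shown sits.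

What the compounds shown leave open is whether any group on this nitrogen can do clearly better, such as a primary amine, a carboxylic acid or a longer chain ending in an amide. They also leave open how the other parts of the shared core contribute, as only this one position varies here.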